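The source may hold more compounds than are shown below. What is called first, only, known or untested is meant among the compounds shown, and "the series" means these compounds.

In an ADME assay on BJ cells (Homo sapiens) for antiproliferative activity, read by MTT assay, with a stated time of 72 h (on this read-out lower numbers stand for stronger inhibition and higher numbers for weaker inhibition), compound 1 `O=c1[nH]c(=O)n(CCC(CO)CO)cc1-c1ccco1` gives 500 nM, compound 2 `CC(=O)OCC(CCn1cc(C#Cc2ccc(Br)cc2)c(=O)n(C(=O)c2ccccc2)c1=O)COC(C)=O` gives 37600 nM, and compound 3 `CCCCCc1ccc(C#Cc2cn(CCC(COC(C)=O)COC(C)=O)c(=O)n(C(=O)c3ccccc3)c2=O)cc1` gives 17600 nM. On these three numbers compound 3 stands second highest: its nearest neighbour is compound 2, and compound 1 lies far below both, which on this read-out means compound 1 is the much stronger inhibitor of the three.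

Compound 4 `CC(=O)OCC(CCn1cc(C#CC(C)(C)C)c(=O)n(C(=O)c2ccccc2)c1=O)COC(C)=O` has not been measured. It differs from compound 3 in one place: tert-butyl in place of 4-pentylphenyl on a triple-bonded carbon. Going by the values given here, the only measured step that touches the same part of the molecule is the one in which the group on the aromatic ring was exchanged, a 2.1-fold lower number from compound 2 to compound 3 (0.33 log units; beyond the scatter), which is a modest shift in the direction of stronger inhibition. That step kept the ring and changed only its substituent, whereas compound 4 removes the whole ring and puts a small branched group in its place, so the earlier step sets the likely size of the effect but not its direction.

Compound 4 is therefore expected to land near compound 3, with any movement probably no larger than the measured step, giving an estimated 1.3-fold higher number from compound 3 to compound 4 (0.10 log units; within the scatter). The estimate for compound 4 is 22000 nM, within a range of 8000 nM to 60000 nM.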

Compound 4, half-maximal inhibitory concentration: 36900 nM
Compound 4: middle estimate off by 1.7-fold (0.22 log units), on the low side, and the stated range covers the measured number.
By their numbers in this assay, from the lowest: compound 1; then compound 3; then compounds 4 and 2 (each within the scatter of the next).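

In this assay, going by these compounds alone, the 4-pentylphenyl group on the triple-bonded carbon gives way to tert-butyl with a 2.1-fold higher number from compound 3 to compound 4 (0.32 log units; beyond the scatter), so the 4-pentylphenyl group is the one of the three groups at this position that stands apart, though only modestly. Exchanging 4-bromophenyl for tert-butyl at the same place gives a 1.0-fold lower number from compound 2 to compound 4 (0.01 log units; within the scatter), which lies within the scatter, so an aromatic ring at this position is not needed to reach the level of compound 2: tert-butyl, with no ring at all, gives a number level with it. Nothing available here explains why these groups give the numbers they do.

The compounds shown leave open whether the pentyl chain or the ring that carries it sets compound 3 apart, which a straight hexyl chain on the triple-bonded carbon, with no ring, could help to separate. They also leave open how a longer chain such as octyl, or an amine, on the aromatic ring would compare with the bromo and pentyl groups.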